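Aryl variation on a saturated ring carbon: cytotoxicity notes

The source may report more compounds than this note shows. Statements on the series, on what has been measured and on what is new or still open speak of the compounds shown alone.

Measured so far:
compound 1 `COc1cc(N2C(N)=C(C#N)C(c3ccc([N+](=O)[O-])cc3)C3=C2CC(C)(C)CC3=O)cc(OC)c1OC`: 50%
compound 2 `COc1cc(N2C(N)=C(C#N)C(c3c(OC)ccc4ccccc34)C3=C2CC(C)(C)CC3=O)cc(OC)c1OC`: 5%
compound 3 `COc1cc(N2C(N)=C(C#N)C(c3cccc([N+](=O)[O-])c3)C3=C2CC(C)(C)CC3=O)cc(OC)c1OC`: 20%

In a functional assay on Ehrlich cells (Mus musculus) for cytotoxicity, tested at 25 ug/mL (on this read-out higher numbers stand for a stronger effect at the one concentration tested and lower numbers for a weaker effect), compound 3 stands second highest of the three numbers; it sits a number 15 percentage points higher from compound 2 to compound 3 (beyond the scatter) and a number 30 percentage points lower from compound 1 to compound 3 (beyond the scatter). Compound 4 `COc1cc(N2C(N)=C(C#N)C(c3ccccc3Cl)C3=C2CC(C)(C)CC3=O)cc(OC)c1OC` has not been measured. The change is 2-chlorophenyl in place of 3-nitrophenyl on a saturated ring carbon. Among the measured compounds shown here, every measured step alters the same aryl group: a number 45 percentage points lower from compound 1 to compound 2 (beyond the scatter), a number 30 percentage points lower from compound 1 to compound 3 (beyond the scatter) and a number 15 percentage points higher from compound 2 to compound 3 (beyond the scatter), so the aryl group clearly moves the read-out, but no step involves 2-chlorophenyl. The three aryl groups span the full range of values, so either direction is possible. An expected step of no change at the digits printed from compound 3 to compound 4 (within the scatter) is therefore about none beyond the scatter, with wide uncertainty. Compound 4 is estimated at 20%, in the range 5% to 45%.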

Compound 4, a percentage reported as activity, at one concentration (the size of the read-out at that concentration, not a potency): 15%
Beside the measured number, compound 4's estimate is 5 percentage points above it; low and high end bracket the measured number.
By their numbers in this assay, from the lowest: compounds 2, 4 and 3 (each within the scatter of the next, the first and the last beyond it); then compound 1.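

In this assay the 2-chlorophenyl group shows a number 5 percentage points lower from compound 3 to compound 4 (within the scatter) and a number 10 percentage points higher from compound 2 to compound 4 (within the scatter) but a number 35 percentage points lower from compound 1 to compound 4 (beyond the scatter). Among the four aryl groups on this saturated ring carbon, only the 4-nitrophenyl of compound 1 stands clear of all the others, and a nitro group alone does not secure that level, as compound 3 carries one yet cannot be separated from compound 4. Nothing at hand explains these differences. Open, on these data alone, is whether 4-chlorophenyl or 4-aminophenyl at this carbon would match compound 1 or fall with the other three.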